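The source may report more compounds than this note shows. Statements on the series, on what has been measured and on what is new or still open speak of the compounds shown alone.

Among the measured compounds shown here, compound 3, `CC(C)c1nc2nc(-c3ccccc3)cc(C(F)(F)F)c2c(=O)n1Cc1cn(CCC(F)(F)C(F)(F)C(F)(F)C(F)(F)C(F)(F)C(F)(F)C(F)(F)C(F)(F)F)nn1`, is the only member of this small set with a measured number: in a functional assay on THP-1 cells (Homo sapiens) for cytotoxicity, read by MTT assay, with a stated time of 24 h (a lower number here means a stronger inhibitor, a higher number a weaker inhibitor), compound 3 gives 142 ug/mL. Its two companions stop at the boundary of the assay. Compound 1, `Cc1nc2nc(-c3ccccc3)cc(C(F)(F)F)c2c(=O)n1Cc1cn(CCC(F)(F)C(F)(F)C(F)(F)C(F)(F)C(F)(F)C(F)(F)C(F)(F)C(F)(F)F)nn1`, returns in this assay only a limit, > 200 ug/mL. Compound 2, `Cc1nc2nc(-c3ccccc3)cc(C(F)(F)F)c2c(=O)n1Cc1cn(-c2ccccc2)nn1`, likewise returns in this assay only a limit, > 200 ug/mL. For the measured compounds named here, the single measured step that bears on the change at hand is an at least 1.4-fold lower number from compound 1 to compound 3 (0.14 log units; that floor lies within the scatter), and its floor is set by the limit of > 200 ug/mL in this assay, at which 2 of the 3 values shown sit, so its true size is unknown. Compound 4, `CCCCCCc1nc2nc(-c3ccccc3)cc(C(F)(F)F)c2c(=O)n1Cc1cn(CCC(F)(F)C(F)(F)C(F)(F)C(F)(F)C(F)(F)C(F)(F)C(F)(F)C(F)(F)F)nn1`, carries the next change at the same position: hexyl in place of isopropyl on an aromatic carbon. Going by the values given here, with only one step of uncertain size available, going from the methyl of compound 1 to the isopropyl of compound 3, the move to hexyl in compound 4 is expected to shift the number in this assay at most modestly, if at all, beyond the scatter; compound 4 is expected to give 100 ug/mL, within 40 ug/mL to 200 ug/mL, corresponding to an expected step of a 1.4-fold lower number from compound 3 to compound 4 (0.15 log units; within the scatter).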

Compound 4, half-maximal inhibitory concentration: > 200 ug/mL
Compound 4: only a limit was reported; the forecaster's own chance of this, stated with the estimate: 30%; middle value at least 2.0-fold (0.30 log units) from the limit.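

In this assay, hexyl on this aromatic carbon, between two ring nitrogen atoms, does not extend the lower number seen with isopropyl; the step runs the other way, an at least 1.4-fold higher number from compound 3 to compound 4 (0.14 log units; that floor lies within the scatter). The compounds shown therefore give no steady trend with chain size at this position: the isopropyl of compound 3 gives the only measured number, while the methyl of compound 1 and the hexyl of compound 4 both end at a limit, and the step between those two cannot be read. The floor of the step to hexyl lies within the scatter, and its true size remains unknown: the limit of > 200 ug/mL in this assay, at which 3 of the 4 values shown sit.

As far as these compounds go, how far compound 4 actually lies from compound 3 stays open. Also open, from the compounds shown here alone, is what an amine or a carboxylic acid on this carbon would give in this assay.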